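The source may hold more compounds than are shown below. What is called first, only, known or untested is meant among the compounds shown, and "the series" means these compounds.

Measured so far in a functional assay on HFF cells (Homo sapiens) for cytotoxicity (on this read-out lower numbers stand for higher toxicity in this test and higher numbers for lower toxicity in this test), for three compounds:
- Compound 1 `CCCSc1nc(N)nc2c1ncn2/C=C1/C[C@@H]1CO` gives 283000 nM
- Compound 2 `Nc1nc(OCC2CC2)c2ncn(/C=C3/C[C@@H]3CO)c2n1` gives 112000 nM
- Compound 3 `C#CCNc1nc(N)nc2c1ncn2/C=C1/C[C@@H]1CO` gives 306000 nM

Compound 2 has the lowest number of the three, which here means the highest toxicity in the test. It stands apart from both others: a 2.5-fold lower number from compound 1 to compound 2 (0.40 log units; beyond the scatter) and a 2.7-fold higher number from compound 2 to compound 3 (0.44 log units; beyond the scatter) are modest steps. Compound 1 and compound 3 show no real difference, with a 1.1-fold higher number from compound 1 to compound 3 (0.03 log units; within the scatter) as the measured step.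

The next compound to be tested is compound 4 `CCCCCSc1nc(N)nc2c1ncn2/C=C1/C[C@@H]1CO`, and the change from compound 2 is pentylsulfanyl in place of cyclopropylmethoxy on an aromatic carbon in a swap of pentylsulfanyl for cyclopropylmethoxy on an aromatic carbon. Its closest measured relative is compound 1, which carries propylsulfanyl in the same place. The step that bears most directly is therefore a 2.5-fold lower number from compound 1 to compound 2 (0.40 log units; beyond the scatter) read in reverse, and it is modest. Among the compounds with values here, no measured pair shows what a longer sulfur-linked chain does, so that part remains open, and only part of that step is expected to return. In this assay the expected change is a 1.3-fold higher number from compound 2 to compound 4 (0.13 log units; within the scatter) as an estimate, so a small rise at most. For compound 4 the estimated value is 150000 nM with an expected range of 60000 nM to 320000 nM around it.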

Compound 4, half-maximal cytotoxic concentration: 215000 nM
Compound 4: the middle estimate sits 1.4-fold (0.16 log units) below what was measured; low and high end bracket the measured number.
By their numbers in this assay, from the lowest: compounds 2, 4, 1 and 3 (each within the scatter of the next, the first and the last beyond it).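

In this assay, within the data shown here, compound 1 and compound 4 form the first pair with two sulfur-linked chains of different length, and the added ethyl makes no real difference (the step is a 1.3-fold lower number from compound 1 to compound 4 (0.12 log units; within the scatter)). Compound 4 also cannot be separated from the compounds with other groups at this position, whether the swap is from cyclopropylmethoxy (a 1.9-fold higher number from compound 2 to compound 4 (0.28 log units; within the scatter)) or from propargylamino (a 1.4-fold lower number from compound 3 to compound 4 (0.15 log units; within the scatter)), so pentylsulfanyl lies within the scatter of all three, even though compound 2 and compound 3 remain apart (a 2.7-fold higher number from compound 2 to compound 3 (0.44 log units; beyond the scatter)). No measurement is available that could explain these numbers, so they describe what happens at this position without saying why.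

Going by these compounds, whether a sulfur-linked chain longer than pentylsulfanyl, such as octylsulfanyl, or a chain ending in an amine or a carboxylic acid would move the number clearly away from that of compound 1 remains open. A straight oxygen-linked chain such as propoxy would also be needed to show whether the lower number of compound 2 goes with its oxygen link or with its three-membered ring.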